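The Same Ring Opening, Carried to a Second Core

The compounds below may be only part of what the source reports. "The series", "measured", "known", "first", "only" and "open" are said of these compounds alone.

Three compounds were measured in an ADME assay on BJ cells (Homo sapiens) for inhibition, read by fluorescence and resazurin assay, with a stated time of 72 h; on this read-out lower numbers stand for stronger inhibition of growth and higher numbers for weaker inhibition of growth. Compound 1 `N[C@H]1CC[C@H](Nc2nc(Nc3ccc(Oc4nccs4)cc3)c3ncn(C4CCCC4)c3n2)CC1` gives 6850 nM in this assay. Compound 2 `NCCCCNc1nc(Nc2ccc(Oc3nccs3)cc2)c2ncn(C3CCCC3)c2n1` differs from it by 4-aminobutyl in place of 4-aminocyclohexyl on a nitrogen on an aromatic ring; in this assay compound 2 gives 18600 nM, and the step amounts to a 2.7-fold higher number from compound 1 to compound 2 (0.43 log units; beyond the scatter). Compound 3 `N[C@H]1CC[C@H](Nc2nc(Nc3ccc(N4CCN(Cc5ccccc5)CC4)cc3)c3ncn(C4CCC(O)C4)c3n2)CC1` carries a different core; how that core differs from the core of compound 1 is not broken down here. In this assay compound 3 gives 16900 nM, a number close to that of compound 2 and higher than that of compound 1.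

Compound 4 `NCCCCNc1nc(Nc2ccc(N3CCN(Cc4ccccc4)CC3)cc2)c2ncn(C3CCC(O)C3)c2n1` has not yet been measured. It stands to compound 3 as compound 2 stands to compound 1: the change is 4-aminobutyl in place of 4-aminocyclohexyl on a nitrogen on an aromatic ring, placed on a nitrogen on an aromatic ring whose other neighbours are aromatic carbon in both pairs, so it is the same change, seen here for the second time. For the measured compounds named here, the only guide to its effect is the single measured instance, in which 4-aminobutyl brought a higher number. If that carries over to the second core, the expected step from compound 3 to compound 4 in this assay is a 2.4-fold higher number from compound 3 to compound 4 (0.37 log units; beyond the scatter). Because the measured step of a 2.7-fold higher number from compound 1 to compound 2 (0.43 log units; beyond the scatter) was modest and seen only once, and because compound 3 already sits at 16900 nM, the expectation is held loosely. Compound 4 is estimated to give 40000 nM in this assay, with a plausible range from 18000 nM to 90000 nM.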

Compound 4, concentration for 50% growth inhibition: 13200 nM
Beside the measured number, compound 4's estimate is 3.0-fold (0.48 log units) above it; the whole stated range lies above it.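

On the second core, 4-aminobutyl in place of 4-aminocyclohexyl gives a 1.3-fold lower number from compound 3 to compound 4 (0.11 log units; within the scatter) and so leaves compound 3 and compound 4 indistinguishable in this assay, whereas on the first core the same change weakened growth inhibition beyond the scatter. The change therefore does not carry from one core to the other as a fixed step, and the two instances differ by more than the scatter allows: the same change on two cores in this assay, a 2.7-fold higher number (0.43 log units; beyond the scatter) from compound 1 to compound 2 and a 1.3-fold lower number (0.11 log units; within the scatter) from compound 3 to compound 4, 3.5-fold (0.54 log units) apart, beyond the scatter of two such steps. For the compounds shown here, this shows that the effect of the chain depends on the core it sits on, but it rests on only two pairs and does not show which feature of the cores lies behind the gap, nor how the change would behave on a third core.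

The compounds shown leave open whether a shorter or longer chain, such as 3-aminopropyl or 6-aminohexyl, or a chain ending in a hydroxyl group instead of an amine, would also depend on the core. They also leave open which of the differences between the two cores matters, as no pair shown alters only one of those differences while keeping the rest of the core fixed.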